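Replacing a methoxyphenyl with a dimethylphenyl on the pyridine amide

The source may hold more compounds than are shown below. What is called first, only, known or untested is meant among the compounds shown, and "the series" means these compounds.

Measured compounds:
compound 1 `CC(C)c1ccc(-c2cc(Cl)cc(C(=O)Nc3nn[nH]n3)n2)cc1`, 14%
compound 2 `COc1cc(C(=O)Nc2nn[nH]n2)nc(-c2ccccc2OC)c1`, 41%
compound 3 `COc1cc(C(=O)Nc2nn[nH]n2)nc(-c2ccc(C(C)(C)C)cc2)c1`, 29%

Of the compounds shown here, three sharing a common core have been tested in a functional assay on the whole organism for inhibition, with Rattus norvegicus as the target, at a dose of 1 mg/kg by the oral route; on this read-out lower numbers stand for a weaker effect and higher numbers for a stronger effect at the one dose given. Compound 2 gives 41% and stands highest of the three numbers. Its nearest neighbour is compound 3, which gives 29%, a number that lies beyond the scatter below compound 2. Furthest away is compound 1, which gives 14%, also beyond the scatter. On these numbers compound 2 is the strongest of the three.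

Compound 4 `COc1cc(C(=O)Nc2nn[nH]n2)nc(-c2ccc(C)c(C)c2)c1` has not been measured in this assay. It differs from compound 2 in one place: 3,4-dimethylphenyl in place of 2-methoxyphenyl on an aromatic carbon. Within the data shown here, no step between two measured compounds corresponds to this change, so its effect has to be judged from the spread of the three values. Compound 2 holds the highest number, and the two other compounds with different aryl groups sit lower, one of them well below.

The estimate for compound 4 is therefore set a little below compound 2, with a step of a number 11 percentage points lower from compound 2 to compound 4 (beyond the scatter) expected in this assay, roughly at the edge of the scatter. Compound 4 is expected to give 30% in this assay, within a range from 15% to 45%.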

Compound 4, a percentage reported as inhibition, in the whole organism at one dose (the size of the read-out at that dose, not a potency): 21%
Estimate against measurement, compound 4: 9 percentage points above; measured number inside the range.
By their numbers in this assay, from the lowest: compounds 1, 4 and 3 (each within the scatter of the next, the first and the last beyond it); then compound 2.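

Among these compounds, exchanging 2-methoxyphenyl for 3,4-dimethylphenyl on the aromatic carbon next to the ring nitrogen gives, in this assay, a number 20 percentage points lower from compound 2 to compound 4 (beyond the scatter), the first step that isolates a change at this position with the rest of the molecule held constant. Compound 3, which carries a tert-butylphenyl group at the same carbon, gives 29%, within the scatter of compound 4 at 21%, so on this core both aryl groups bearing only alkyl substituents lie beyond the scatter below compound 2, with no order between them. Nothing measured here accounts for the step, so the data give no reason for it.

The compounds shown cannot separate the loss of the methoxy group from the shift of substituents around the phenyl ring, since both happen in the one step. From the compounds shown here alone, a 2-methylphenyl or a 3,4-dimethoxyphenyl group at this carbon would tell these two apart, and whether a phenyl ring carrying an amine or a carboxylic acid fits this trend stays open.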